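Adding a nitro group to a phenyl-oxadiazole propanone

The source may report more compounds than this note shows. Statements on the series, on what has been measured and on what is new or still open speak of the compounds shown alone.

Compound 1 `O=C(CCc1nnc(-c2ccccc2)o1)c1ccccc1` gives 29.4% in a functional assay on the whole organism (strain Wistar) for inhibition, with Rattus norvegicus as the target, with stated times of 30 min and 3 h, at a dose of 20 mg/kg by the oral route; a lower number here means less inhibition, a higher number more inhibition at the dose given (going by the name of the read-out). Compound 2 `Cc1ccc(C(=O)CCc2nnc(-c3ccccc3)o2)cc1` gives 49.3%, the higher of the two numbers measured, and the step of a number 19.9 percentage points higher from compound 1 to compound 2 (beyond the scatter) is the only one recorded. Compound 3 `Cc1ccc(C(=O)CCc2nnc(-c3ccc([N+](=O)[O-])cc3)o2)cc1` differs from compound 2 by nitro in place of hydrogen on an aromatic carbon. Among the measured compounds shown here, no measured step involves a nitro group, so the methyl step gives only a loose guide, showing that a single change on an aromatic carbon can shift the read-out modestly. For compound 3 the expected step is a number 0.7 percentage points higher from compound 2 to compound 3 (within the scatter), within the scatter. Compound 3 is therefore estimated at 50%, with a range from 30% to 70%.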

Compound 3, a percentage reported as inhibition, in the whole organism at one dose (the size of the read-out at that dose, not a potency): 60.5%
Compound 3: the middle estimate sits 10.5 percentage points below what was measured; the measured number falls inside the stated range.
By their numbers in this assay, from the lowest: compound 1; then compound 2; then compound 3.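

With a number 11.2 percentage points higher from compound 2 to compound 3 (beyond the scatter) in this assay, nitro in place of hydrogen on an aromatic carbon, para to a large group, adds to the gain already seen with the methyl. Methyl and nitro can therefore sit in one molecule without the read-out dropping. Nothing shown here explains why the number rose.

On these data alone, it remains open whether an amine or a carboxylic acid at this same place would give a similar number. As far as these compounds go, the effect of nitro in a compound without the methyl also remains open.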